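Swapping Acetyl for Ethyl on a Compound at the Limit

The source may report more compounds than this note shows. Statements on the series, on what has been measured and on what is new or still open speak of the compounds shown alone.

In a functional assay on MCF7 cells (Homo sapiens) for antiproliferative activity, with a stated time of 48 h (on this read-out higher numbers stand for weaker inhibition and lower numbers for stronger inhibition), compound 3 (`CC(=O)Oc1ccc(C(=O)/C=C/c2ccccc2)c(O)c1`) gives > 50000 nM, which is a limit of the assay and not a number. Compound 1 (`CCCOc1ccc(C(=O)/C=C/c2ccccc2)c(O)c1`) gives > 50000 nM, also a limit. Compound 2 (`O=C(/C=C/c1ccccc1)c1ccc(OCc2ccccc2)cc1O`) gives > 50000 nM, again a limit. Compound 3 therefore has no exact position on the scale, and it shares the limit of > 50000 nM in this assay, at which 3 of the 3 values shown sit, with the other two.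

Compound 4 (`CCOc1ccc(C(=O)/C=C/c2ccccc2)c(O)c1`) differs from compound 3 in one place, with ethyl in place of acetyl on an oxygen on an aromatic ring.

The measured steps that bear on this change also alter the group on that oxygen. They are a step that the two limits leave unreadable from compound 1 to compound 3 and a step that the two limits leave unreadable from compound 2 to compound 3, and between the other two compounds there is a step that the two limits leave unreadable from compound 1 to compound 2. None of them has a readable size, so they offer no direction. Within the data shown here, still, acetyl, propyl and benzyl on that oxygen all end at the same limit, and no compound here goes against this.

The expected change is no more than the scatter, and the estimated step is a step that the limit leaves unreadable from compound 3 to compound 4. For compound 4 the estimated value is 60000 nM, within an expected range from 30000 nM to 150000 nM, and the assay may well report only a limit again.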

Compound 4, half-maximal inhibitory concentration: > 50000 nM
Compound 4: only a limit was reported (the forecaster's own chance of this, stated with the estimate: 85%); the middle value is on the limit's open side.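

Compound 4, like compound 1, compound 2 and compound 3, has only a limit of the assay in this assay, so no step among these four compounds can be read: the limit of > 50000 nM in this assay, at which 4 of the 4 values shown sit.

The compounds shown leave open whether acetyl, ethyl, propyl and benzyl on that oxygen differ at all in their effect on these cells.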